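Dimethoxyphenyl for dichlorophenyl on the carbonyl side

The source may hold more compounds than are shown below. What is called first, only, known or untested is meant among the compounds shown, and "the series" means these compounds.

Measured compounds:
- compound 1 `COc1cc(-c2cc(/C=C/C(=O)c3ccc(Cl)c(Cl)c3)[nH]n2)cc(OC)c1OC`: 1260 nM
- compound 2 `COc1ccc(-c2cc(/C=C/C(=O)c3ccc(N)cc3)[nH]n2)cc1OC`: 1880 nM
- compound 3 `COc1ccc(-c2cc(/C=C/C(=O)c3ccc(N)cc3)[nH]n2)cc1`: 1850 nM

In a functional assay on COLO 205 cells (Homo sapiens) for inhibition, read by sulforhodamine B assay, with a stated time of 48 h (on this read-out higher numbers stand for weaker inhibition of growth and lower numbers for stronger inhibition of growth), compound 1 gives 1260 nM, the lowest of the three numbers, yet both other compounds lie within the scatter of it, so no order among them can be claimed. For the measured compounds named here, compound 2 gives 1880 nM and compound 3 gives 1850 nM; the one step that connects two measured compounds, a 1.0-fold lower number from compound 2 to compound 3 (0.01 log units; within the scatter), shows that removing a methoxy on the ring attached to the shared core leaves the read-out unchanged.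

The unmeasured compound 4 `COc1ccc(C(=O)/C=C/c2cc(-c3cc(OC)c(OC)c(OC)c3)n[nH]2)cc1OC` differs from compound 1 in one place: 3,4-dimethoxyphenyl in place of 3,4-dichlorophenyl on a carbonyl carbon. Going by the values given here, no measured step touches the aryl group on the carbonyl carbon, so this change is unprecedented here. What can be said is that compound 1, compound 2 and compound 3, which carry different groups on both ends of the shared core, all give numbers within the scatter of one another, suggesting the read-out is not very sensitive to such substitutions. Compound 4 is therefore expected to show a step of a 1.2-fold higher number from compound 1 to compound 4 (0.08 log units; within the scatter), with no direction favoured beyond the scatter. The estimate for compound 4 is 1500 nM, ranging from 600 nM to 4000 nM.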

Compound 4, concentration for 50% growth inhibition: 1740 nM
For compound 4 the middle estimate is 1.2-fold (0.06 log units) below the measured one, within the range that was stated.
By their numbers in this assay, from the lowest: compounds 1, 4, 3 and 2 (each within the scatter of the next).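

In this assay, for the compounds shown here, putting 3,4-dimethoxyphenyl in place of 3,4-dichlorophenyl on the carbonyl carbon gives a 1.4-fold higher number from compound 1 to compound 4 (0.14 log units; within the scatter), the first one-place reading at this position, and no difference between the two groups can be claimed from it. The exchange replaces two chlorine atoms with two methoxy groups, taking the group from 8 to 10 heavy atoms and from 0 to 2 hydrogen-bond acceptors, and this change in counts does not separate compound 4 from compound 1 on this read-out. Nothing available here bears on why the two compounds fall within the scatter of each other.

This single pair cannot show whether any group on the carbonyl carbon would move the number beyond the scatter, for instance an aryl group carrying a carboxylic acid or a dimethylamino group in place of the chlorines or methoxy groups. The aminophenyl group of compound 2 and compound 3 also remains unconnected to this position, since neither compound differs from compound 1 or compound 4 in only one place.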